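Clearance notes: one fluoro lost from compound 2

The source may hold more compounds than are shown below. What is called first, only, known or untested is meant among the compounds shown, and "the series" means these compounds.

Measured in an ADME assay on the whole organism (plasma, strain Sprague-Dawley) for pharmacokinetics, with Rattus norvegicus as the target, read by LC-MS; on this read-out higher numbers stand for fast clearance and lower numbers for slow clearance:
- compound 1 `Cn1c(-c2cccnc2)nc2ccc(F)cc21` gives 59 mL/min/kg
- compound 2 `Fc1cc2nc(-c3cccnc3)n(C3CC3)c2cc1F` gives 43 mL/min/kg

Compound 2 at 43 mL/min/kg stands within the scatter of compound 1 at 59 mL/min/kg and the two values cannot be told apart. For the measured compounds named here, these are the only two numbers so far. Going by the values given here, no two measured compounds differ in a single place, so the data give no direct size for any one structural change.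

The next compound to be read is compound 3 `Fc1ccc2nc(-c3cccnc3)n(C3CC3)c2c1`, which has hydrogen in place of fluoro on an aromatic carbon relative to compound 2. The site is ortho to a fluoro group, which stays in place.

With so little to go on, no shift beyond the scatter is expected in this assay, and no firm direction can be given. The expected size is the estimated step of a 1.2-fold higher number from compound 2 to compound 3 (0.07 log units; within the scatter) and it counts as small. For compound 3 the estimated clearance is 50 mL/min/kg with an expected range from 28 mL/min/kg to 85 mL/min/kg in this assay as the measure.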

Compound 3, clearance: 28 mL/min/kg
Compound 3: middle estimate off by 1.8-fold (0.25 log units), on the high side; low and high end bracket the measured number.
By their numbers in this assay, from the lowest: compounds 3, 2 and 1 (each within the scatter of the next, the first and the last beyond it).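

In this assay, hydrogen in place of fluoro on the aromatic carbon ortho to the remaining fluoro group gives a 1.5-fold lower number from compound 2 to compound 3 (0.19 log units; within the scatter), so this position has no effect on clearance that can be separated from the scatter, and the second fluoro group can be dropped without a measurable penalty or gain here. For the compounds shown here, the comparison of compound 1 with compound 3 isolates a different place, with cyclopropyl in place of methyl on the aromatic nitrogen, and gives a 2.1-fold lower number from compound 1 to compound 3 (0.32 log units; beyond the scatter), the first single change to lie beyond the scatter, though only modestly. No measurement available here accounts for either step.

From the compounds shown here alone, whether a larger or different group on the same aromatic carbon, such as chloro, methoxy or a nitrile, would move clearance beyond the scatter remains open. Going by these compounds, it is also open whether the step at the aromatic nitrogen extends to other groups there, such as ethyl, isopropyl or cyclobutyl, or holds with the second fluoro group in place.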